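The source may hold more compounds than are shown below. What is called first, only, known or untested is meant among the compounds shown, and "the series" means these compounds.

Compounds measured in a functional assay on A549 cells (Homo sapiens) for antiproliferative activity, read by MTT assay, with a stated time of 48 h; on this read-out higher numbers stand for weaker inhibition and lower numbers for stronger inhibition:

Compound 1, `COc1ccccc1-n1cc(COC(=O)/C(C)=C/CC/C(C)=C/CC/C(C)=C/CC[C@@H]2[C@@]3(C)CCC(=O)C(C)(C)[C@H]3CC[C@@]2(C)O)nn1`; in this assay compound 1 gives the limit > 150000 nM.
Compound 2, `C/C(=C\CC/C(C)=C/CC[C@@H]1[C@@]2(C)CCC(=O)C(C)(C)[C@H]2CC[C@@]1(C)O)CC/C=C(\C)C(=O)OCc1cn(-c2ccc(C(F)(F)F)cc2)nn1`; in this assay compound 2 gives the limit > 150000 nM.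
Compound 3, `C/C(=C\CC/C(C)=C/CC[C@@H]1[C@@]2(C)CCC(=O)C(C)(C)[C@H]2CC[C@@]1(C)O)CC/C=C(\C)C(=O)OCc1cn(-c2cccc([N+](=O)[O-])c2)nn1`; in this assay compound 3 gives the limit > 150000 nM.

Compound 3 thus stands at the limit of > 150000 nM in this assay, at which 3 of the 3 values shown sit, as do the other two. The steps a step that the two limits leave unreadable from compound 1 to compound 2, a step that the two limits leave unreadable from compound 1 to compound 3 and a step that the two limits leave unreadable from compound 2 to compound 3 give no readable size. Compound 4, `C/C(=C\CC/C(C)=C/CC[C@@H]1[C@@]2(C)CCC(=O)C(C)(C)[C@H]2CC[C@@]1(C)O)CC/C=C(\C)C(=O)OCc1cn(-c2cccc(O)c2)nn1`, differs from compound 3 by hydroxy in place of nitro on an aromatic carbon. Among the compounds with values here, no measured step bears on this change, so no direction can be read from the numbers. He expects compound 4 to remain near the limit, with a number no higher from compound 3 to compound 4 (the limit leaves the size open) as the step, and estimates compound 4 at 150000 nM, between 40000 nM and 500000 nM.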

Compound 4, half-maximal inhibitory concentration: 42800 nM
Compound 4: the middle estimate sits 3.5-fold (0.54 log units) above what was measured, and the stated range covers the measured number.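

In this assay, within the data shown here, hydroxy in place of nitro on the aromatic ring gives an at least 3.5-fold lower number from compound 3 to compound 4 (0.54 log units; beyond the scatter), the first readable change at this position. The 3-hydroxyphenyl group also gives an at least 3.5-fold lower number from compound 2 to compound 4 (0.54 log units; beyond the scatter) and an at least 3.5-fold lower number from compound 1 to compound 4 (0.54 log units; beyond the scatter). The steps among compound 1, compound 2 and compound 3 cannot be read, and only compound 4 leaves the limit: the limit of > 150000 nM in this assay, at which 3 of the 4 values shown sit.

On these data alone, the true size of each step stays open, since one end of each is a limit. Also open, as far as these compounds go, is how an amine or a carboxylic acid in place of the hydroxy group would read.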